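Dropping the bromine from compound 1: what to expect

The source may report more compounds than this note shows. Statements on the series, on what has been measured and on what is new or still open speak of the compounds shown alone.

Measured so far:
- compound 1 `S=C(N/N=C/c1ccc2ccccc2n1)Nc1ccc(Br)cc1`: 69400 nM
- compound 2 `CN(C)C(=S)N/N=C/c1cnc2ccccc2n1`: 170 nM
- compound 3 `Cc1csc2sc(/C=N/NC(N)=S)c(C)c12`: a limit, > 100000 nM

In a functional assay on SGC-7901 cells (Homo sapiens) for antiproliferative activity, read by sulforhodamine B assay, with a stated time of 72 h (on this read-out lower numbers stand for stronger inhibition and higher numbers for weaker inhibition), compound 1 gives 69400 nM. Compound 2 gives 170 nM in this assay, a far lower number, well beyond the scatter. For compound 3 the this assay result is only a limit, > 100000 nM, so no number is known for it. Among the two numbers, compound 1 therefore holds the highest one, meaning the weakest inhibition.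

Compound 4 `S=C(N/N=C/c1ccc2ccccc2n1)Nc1ccccc1` differs from compound 1 in one place: hydrogen in place of bromo on an aromatic carbon. For the measured compounds named here, no pair of measured compounds shows this same change, so there is no measured step to lean on. A change this small, at a ring edge far from the rest of the molecule, is expected to move the number little, if at all beyond the scatter, with a slight lean toward weaker inhibition. The step from compound 1 to compound 4 is estimated at a 1.2-fold higher number from compound 1 to compound 4 (0.09 log units; within the scatter). For compound 4 the expected value in this assay is 85000 nM, with a range from 25000 nM to 300000 nM.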

Compound 4, half-maximal inhibitory concentration: 26500 nM
Compound 4: the middle estimate sits 3.2-fold (0.51 log units) above what was measured, and the stated range covers the measured number.
By their numbers in this assay, from the lowest: compound 2; then compound 4; then compound 1. At a limit, above all of these: compound 3.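

In this assay the change from 4-bromophenyl to phenyl gives a 2.6-fold lower number from compound 1 to compound 4 (0.42 log units; beyond the scatter), so this position on the ring does respond to a change, even one as small as a single bromine atom giving way to hydrogen. The step runs toward stronger inhibition, which shows that the bromo group is not required for the activity of this series and that, in this pair, compound 4 does better without it. Nothing available here explains why the number moves in this direction.

From the compounds shown here alone, whether the gain would continue with other groups in this place stays open, since a single step cannot show a trend, and a methoxy group or an amine on the same carbon would be informative. Also open, going by these compounds, is whether the same change would have a similar effect on a different core.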